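The source may hold more compounds than are shown below. What is called first, only, known or untested is meant among the compounds shown, and "the series" means these compounds.

Working notes on the series. Compound 1 `COc1ccc(-c2cnco2)cc1NCc1cccs1` is the starting point for the step to compound 4 `COc1ccc(-c2cnco2)cc1NCc1ccc(C)s1`. In an ADME assay on Huh-7 cells (Homo sapiens) for cytotoxicity, read by MTT assay, with a stated time of 96 h (a lower number here means that less compound is tolerated, a higher number that more compound is tolerated), compound 1 returns only a limit, > 100000 nM. Compound 2 `COc1cc(/N=C/c2ccc(F)cc2)ccc1-c1cnco1` also returns only a limit in this assay, > 100000 nM. Compound 3 `COc1cc(NCc2ccncc2)ccc1-c1cnco1` gives a numerical value in this assay, 72200 nM. For the measured compounds named here, compound 1 therefore stands at the limit of > 100000 nM in this assay, at which 2 of the 3 values shown sit, and no measured step between any two compounds is available to calibrate the change.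

Compound 4 differs from compound 1 by methyl in place of hydrogen on an aromatic carbon. Going by the values given here, with no measured step of this kind, no shift beyond the usual scatter is expected in this assay, and compound 4 is estimated to sit near the same limit as compound 1. The estimate for compound 4 is 100000 nM, within 50000 nM to 200000 nM, meaning an expected step of a number no higher from compound 1 to compound 4 (the limit leaves the size open).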

Compound 4, half-maximal cytotoxic concentration: 52900 nM
Compound 4: middle estimate off by 1.9-fold (0.28 log units), on the high side; low and high end bracket the measured number.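

In this assay methyl in place of hydrogen next to the ring sulfur gives an at least 1.8-fold lower number from compound 1 to compound 4 (0.27 log units; that floor lies within the scatter) and yields a number where the unsubstituted thiophen-2-yl compound had none. Only the floor of this step is known, so the data do not establish a shift beyond the scatter. Compound 1 stands as a limit and not a number: the limit of > 100000 nM in this assay, at which 2 of the 4 values shown sit.

From the compounds shown here alone, the true size of the step remains open. So does the outcome at this same ring carbon with ethyl, a chlorine atom or a carboxylic acid in place of methyl.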